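From (methylsulfonyl)oxy to (3-aminopropyl)amino on a shared core

This account rests on a few compounds, and the source may have more. Where it says the series, first, only, none or still open, it means among the compounds named here.

Compound 2 `CS(=O)(=O)Oc1c(C(=O)NCc2ccc(F)cc2)nc(Br)c2cccnc12` was tested in a functional assay on HCT-116 cells (Homo sapiens) for cytotoxicity, read by MTT assay, with a stated time of 72 h (a higher number here means a weaker inhibitor, a lower number a stronger inhibitor), and it gives only a limit of the assay, > 20000 nM, not a number. Compound 1 `N[C@H]1CC[C@H](Nc2c(C(=O)NCc3ccc(F)cc3)nc(N3CCCCS3(=O)=O)c3cccnc23)CC1` also gives only a limit, > 10000 nM. Compound 3 `O=C(NCc1ccc(F)cc1)c1nc(Br)c2cccnc2c1NCCCNc1c(C(=O)NCc2ccc(F)cc2)nc(Br)c2cccnc12` likewise stops at a limit, > 20000 nM. So far, then, every value is a limit, the limit of > 20000 nM in this assay, at which 2 of the 3 values shown sit, and (the limit of > 10000 nM in this assay, at which 1 of the 3 values shown sits), and no measured compound shows inhibition that could be quantified in this assay. Compound 4 `NCCCNc1c(C(=O)NCc2ccc(F)cc2)nc(Br)c2cccnc12` differs from compound 2 in a single place: (3-aminopropyl)amino in place of (methylsulfonyl)oxy on an aromatic carbon. Among the measured compounds shown here, no pair of measured compounds differs in one place, so no measured step exists to guide the size or direction of this change, and a step beyond the usual scatter cannot be predicted. Compound 4 is therefore expected to land around 15000 nM, within a range of 3000 nM to 60000 nM. The expected step in this assay is an at least 1.3-fold lower number from compound 2 to compound 4 (0.12 log units; that floor lies within the scatter).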

Compound 4, half-maximal inhibitory concentration: 18000 nM
Compound 4: the middle estimate sits 1.2-fold (0.08 log units) below what was measured; low and high end bracket the measured number.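

Among the compounds shown here, compound 4, at 18000 nM in this assay, gives the first real number, so this position can carry a group that brings the value within the range of the assay. Compound 2, at > 20000 nM, gives only a limit and not a number. Going by these compounds, putting (3-aminopropyl)amino in place of (methylsulfonyl)oxy therefore gives only a floor, an at least 1.1-fold lower number from compound 2 to compound 4 (0.04 log units; that floor lies within the scatter), and the true size of the step stays unknown.

On these data alone, whether a longer chain or a simple amino group on this aromatic carbon would lower the number further remains open. So does whether a carboxylic acid at the end of the chain would do the same as the amine.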